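Chain Extension on Compound 2 and Its Expected Effect

The source may hold more compounds than are shown below. What is called first, only, known or untested is meant among the compounds shown, and "the series" means these compounds.

Measured compounds:
Compound 1, `CC(C)=CCC1Cc2c(O)cc(=O)n(CCCO)c2CC1(C)C`: in a functional assay on PANC-1 cells (Homo sapiens) for inhibition, read by MTT assay, with a stated time of 24 h, tested at 10 uM (a higher number here means more inhibition at the concentration tested (going by the name of the read-out), a lower number less inhibition), compound 1 gives 0%.
Compound 2, `COc1cccc(NC(=O)Oc2cc(=O)n(CCCO)c3c2CC(CC=C(C)C)C(C)(C)C3)c1`: in this assay compound 2 gives 0%.
Compound 3, `CC(C)=CCC1Cc2c(OC(=O)Nc3ccc(Cl)c(Cl)c3)cc(=O)n(CCCO)c2CC1(C)C`: in this assay compound 3 gives 1.8%.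

Compound 2 stands level with compound 1, the two together the lowest of the three numbers; its furthest neighbour is compound 3, with a number 1.8 percentage points higher from compound 2 to compound 3 (within the scatter). Compound 4, `COc1cccc(NC(=O)Oc2cc(=O)n(CCCO)c3c2CC(C/C=C(\C)CCC=C(C)C)C(C)(C)C3)c1`, differs from compound 2 in one place: 3-methylbut-2-en-1-yl in place of hydrogen on a saturated chain carbon bound to a double-bonded chain carbon. Going by the values given here, none of the measured steps touches this position. All three, no change at the digits printed from compound 1 to compound 2 (within the scatter), a number 1.8 percentage points higher from compound 1 to compound 3 (within the scatter) and a number 1.8 percentage points higher from compound 2 to compound 3 (within the scatter), concern the carbamoyl part and stay within the scatter, so there is no basis for expecting a step beyond the scatter here either. Compound 4 is therefore expected to give 3% in this assay, between 0% and 12%. The expected step is a number 3 percentage points higher from compound 2 to compound 4 (within the scatter).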

Compound 4, a percentage reported as inhibition, at one concentration (the size of the read-out at that concentration, not a potency): 11.3%
Compound 4: middle estimate off by 8.3 percentage points, on the low side; measured number inside the range.
By their numbers in this assay, from the lowest: compounds 1, 2, 3 and 4 (each within the scatter of the next, the first and the last beyond it).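

In this assay, going by these compounds alone, this position is the first to move the number beyond the scatter: 3-methylbut-2-en-1-yl on a saturated chain carbon bound to a double-bonded chain carbon gives a number 11.3 percentage points higher from compound 2 to compound 4 (beyond the scatter) and makes the side chain 3,7-dimethylocta-2,6-dien-1-yl. The steps in the carbamoyl part, among compound 1, compound 2 and compound 3, all stayed within the scatter. Nothing available explains this step.

On these data alone, it remains open whether a longer chain, or a carboxylic acid in place of the 3-methylbut-2-en-1-yl, would change the number further. As far as these compounds go, it also remains open whether the same extension would give a similar step with the 3,4-dichlorophenyl carbamate of compound 3.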